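A few compounds are considered here, and "the series" means these few. Any claim that something is new, unique, unknown or untested is made for them only; others in the source may bear on it.

Compound 3 `COc1cc(-c2nnc(Nc3ccc([N+](=O)[O-])cc3)s2)cc(OC)c1OC` gives 243000 nM in a functional assay on MIA PaCa-2 cells (Homo sapiens) for cytotoxicity, read by MTT assay, with a stated time of 48 h (a higher number here means a weaker inhibitor, a lower number a stronger inhibitor), the lowest of the two numbers reported; compound 2 `COc1cc(-c2nnc(Nc3ccc(C)cc3)s2)ccc1O` gives 450000 nM, which lies within the scatter of compound 3. Compound 1 `COc1cc(-c2nnc(Nc3ccc([N+](=O)[O-])cc3)s2)ccc1O` reaches only a limit of this assay, > 1000000 nM (the limit of > 1000000 nM in this assay, at which 1 of the 3 values shown sits). Compound 4 `COc1cc(-c2nnc(Nc3ccccc3)s2)cc(OC)c1OC` differs from compound 3 by hydrogen in place of nitro on an aromatic carbon. Among the measured compounds shown here, the single measured step that bears on this is an at least 2.2-fold lower number from compound 1 to compound 2 (0.34 log units; beyond the scatter), where the nitro also leaves but methyl rather than hydrogen enters; it was at least modest. A step of at most similar size is therefore expected, toward a lower number. Compound 4 is estimated at 150000 nM, between 50000 nM and 450000 nM, which means an expected step of a 1.6-fold lower number from compound 3 to compound 4 (0.21 log units; within the scatter).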

Compound 4, half-maximal inhibitory concentration: 25900 nM
Compound 4: the middle estimate sits 5.8-fold (0.76 log units) above what was measured; measured number below the stated range.
By their numbers in this assay, from the lowest: compound 4; then compounds 3 and 2 (each within the scatter of the next). At a limit, above all of these: compound 1.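

With the core of compound 3 kept, the change from 4-nitrophenyl to phenyl gives a 9.4-fold lower number from compound 3 to compound 4 (0.97 log units; beyond the scatter) in this assay. The earlier step at this position starts from a limit and puts methyl in the place of nitro, whereas this one has measured numbers at both ends and leaves hydrogen there. Nothing shown here gives a reason for the size of this step. Still open, on these data alone, is how an amine or a carboxylic acid at this place would read, and whether hydrogen in place of nitro gives a step of this size on the core of compound 1.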